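Working notes: from compound 2 to compound 3

The compounds below may be only part of what the source reports. "The series", "measured", "known", "first", "only" and "open" are said of these compounds alone.

Measured so far in a functional assay on HL-60 cells (Homo sapiens) for cytotoxicity, read by WST assay, with a stated time of 48 h; a higher number here means that more compound is needed for the effect, a lower number that less compound is needed:
- compound 1 `COc1cccc(C[C@H]2COC(=O)[C@@H]2Cc2ccc(Cl)c(Cl)c2)c1` gives 34000 nM
- compound 2 `O=C1OC[C@H](Cc2cccc(F)c2)[C@H]1Cc1ccc(Cl)c(Cl)c1` gives 14000 nM

Going by the values given here, compound 2 at 14000 nM holds the lower of the two numbers, and compound 1 is its only neighbour. Among the compounds with values here, the one measured step is a 2.4-fold lower number from compound 1 to compound 2 (0.39 log units; beyond the scatter), with fluoro in place of methoxy on an aromatic carbon. It is modest but beyond the scatter.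

The next compound is compound 3 `COc1ccc(C[C@H]2COC(=O)[C@@H]2Cc2ccc(Cl)c(Cl)c2)cc1`, not yet measured. The change is 4-methoxyphenyl in place of 3-fluorophenyl on a saturated chain carbon bound to a saturated ring carbon.

This change trades fluoro for methoxy, the opposite of the measured step, so a modest rise in this assay is expected. Within the data shown here, the only methoxy value in hand is that of compound 1 at 34000 nM, and it anchors the expectation. Among the measured compounds shown here, no measured compound shows the 4-methoxyphenyl itself, so the range stays wide.

The expected step is a 2.1-fold higher number from compound 2 to compound 3 (0.33 log units; beyond the scatter), and it may not clear the scatter.

For compound 3 the estimated value is 30000 nM, with an expected range from 12000 nM to 70000 nM.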

Compound 3, half-maximal effective concentration: 37000 nM
For compound 3 the middle estimate is 1.2-fold (0.09 log units) below the measured one; measured number inside the range.
By their numbers in this assay, from the lowest: compound 2; then compounds 1 and 3 (each within the scatter of the next).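

In this assay, the swap of 3-fluorophenyl for 4-methoxyphenyl on a saturated chain carbon bound to a saturated ring carbon gives a 2.6-fold higher number from compound 2 to compound 3 (0.42 log units; beyond the scatter), so compound 2 now stands apart from two methoxy compounds rather than one. The comparison between the two methoxy compounds is new: 4-methoxyphenyl in place of 3-methoxyphenyl gives a 1.1-fold higher number from compound 1 to compound 3 (0.04 log units; within the scatter), so this assay does not separate these two groups, and in this small set the methoxy compounds sit together while the 3-fluorophenyl compound has the lowest number. No measurement at hand explains the difference between the fluoro and methoxy compounds.

The compounds shown leave open whether the lower number of compound 2 goes with fluoro in general or with the 3-fluorophenyl group specifically, and what a 4-fluorophenyl group or an unsubstituted phenyl would give in this assay. Also open, going by these compounds, is whether a quite different substituent on this ring, such as an amine or a carboxylic acid, would move the number beyond the small steps seen so far.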